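The compounds below may be only part of what the source reports. "The series", "measured", "known", "first", "only" and "open" are said of these compounds alone.

Measured compounds in a functional assay on the whole organism with Mus musculus as the target; a higher number here means a larger maximal response, a lower number a smaller maximal response:

compound 1, `CCn1c(=O)n(C2OC(CO)[C@@H](O)[C@H]2O)c2nc(N)nc(O)c21`, gives 82%
compound 2, `CCCCCCCCCCn1c(=O)n(C2OC(CO)[C@@H](O)[C@H]2O)c2nc(N)nc(O)c21`, gives 0%
compound 3, `CCCCn1c(=O)n(C2OC(CO)[C@@H](O)[C@H]2O)c2nc(N)nc(O)c21`, gives 70%

Compound 3 stands second highest of the three; compound 1 is its nearest neighbour and compound 2 its furthest. The unmeasured compound 4, `Nc1nc(O)c2c(n1)n(C1OC(CO)[C@@H](O)[C@H]1O)c(=O)n2CCN1CCCCC1`, differs from compound 3 by piperidin-1-yl in place of ethyl on a saturated chain carbon, two bonds along the chain from an aromatic nitrogen.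

Among the measured compounds shown here, three measured steps touch the same place or the same kind of group. Adding ethyl there gave a number 12 percentage points lower from compound 1 to compound 3 (beyond the scatter), a modest drop. Adding octyl instead gave a number 82 percentage points lower from compound 1 to compound 2 (beyond the scatter), a large drop. Removing hexyl further along gave a number 70 percentage points higher from compound 2 to compound 3 (beyond the scatter), a large gain. Among the measured compounds, a bigger group at this place has gone with a lower maximal response, and the response fell faster as the group grew. The group entering in compound 4 is larger than ethyl, though it is a ring holding a nitrogen rather than a plain chain, and nothing measured here shows what such a ring does. A drop beyond the scatter is therefore expected, but its size is uncertain; the estimated step is a number 25 percentage points lower from compound 3 to compound 4 (beyond the scatter). Compound 4 is expected to give 45%, within 10% to 80%.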

Compound 4, largest response reached (reported as maximal response), in percent of the reference or control that the assay uses: 0%
Compound 4: the middle estimate sits 45 percentage points above what was measured, outside the stated range (below it).
By their numbers in this assay, from the lowest: compounds 2 and 4 (each within the scatter of the next); then compound 3; then compound 1.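

In this assay, swapping ethyl for piperidin-1-yl on the saturated chain carbon, two bonds along the chain from an aromatic nitrogen, gives a number 70 percentage points lower from compound 3 to compound 4 (beyond the scatter) and, measured against the compound with only hydrogen there, a number 82 percentage points lower from compound 1 to compound 4 (beyond the scatter) so this place accepts ethyl with a modest loss but not this ring. Among the compounds shown here, the ring also cannot be told apart from octyl, with no change at the digits printed from compound 2 to compound 4 (within the scatter) so a long plain chain is not the only kind of group that removes the response here, which the earlier compounds could not show. Nothing available explains why the response disappears with either group.

The compounds shown leave open whether the ring itself or its nitrogen goes with the loss, and cyclohexyl, an all-carbon ring, or an open-chain amine such as diethylamino would help separate the two. They also leave open how large a group this place accepts, since nothing shown lies between ethyl and these two much larger groups, a gap that a propyl or butyl chain would begin to fill.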